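The source may hold more compounds than are shown below. What is called first, only, known or untested is meant among the compounds shown, and "the series" means these compounds.

For the measured compounds named here, compound 2, `N#Cc1ccc(COc2ccc3c(c2)CCCC3=O)cc1`, gives 656 nM in an assay on isolated protein for inhibition of Amine oxidase [flavin-containing] A (Homo sapiens), read by fluorescence and spectrophotometry, with a stated time of 30 min (on this read-out lower numbers stand for stronger inhibition and higher numbers for weaker inhibition), the higher of the two numbers measured so far; the other belongs to compound 1, `O=C1CCCc2cc(OCc3ccc(Br)cc3)ccc21`, which gives 311 nM. Compound 3, `O=C1CCCc2cc(OCc3ccc(C(F)(F)F)cc3)ccc21`, differs from compound 2 by trifluoromethyl in place of cyano on an aromatic carbon. Going by the values given here, only one measured step bears on this change, a 2.1-fold higher number from compound 1 to compound 2 (0.32 log units; beyond the scatter), and it involved neither of the groups now exchanged. Since that single step was modest, a step of similar size is expected, in the direction of a lower number, namely a 1.6-fold lower number from compound 2 to compound 3 (0.21 log units; within the scatter). Compound 3 is therefore estimated at 400 nM, within 200 nM to 800 nM.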

Compound 3, half-maximal inhibitory concentration: 547 nM
The estimate for compound 3 lay 1.4-fold (0.14 log units) below the measured number, and the stated range covers the measured number.
By their numbers in this assay, from the lowest: compounds 1, 3 and 2 (each within the scatter of the next, the first and the last beyond it).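

In this assay, trifluoromethyl in place of cyano, para to a large group, gives a 1.2-fold lower number from compound 2 to compound 3 (0.08 log units; within the scatter) and so cannot be told apart from cyano at this position. Trifluoromethyl in place of bromo gives a 1.8-fold higher number from compound 1 to compound 3 (0.25 log units; within the scatter) and likewise cannot be told apart from bromo, leaving the step between compound 1 and compound 2 as the only one beyond the scatter. No measurement offered here explains these small differences. From the compounds shown here alone, whether an amine or a carboxylic acid on this carbon would give a number clearly apart from these three remains open.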